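Methoxy on the indole ring of an isoxazoline series

The source may hold more compounds than are shown below. What is called first, only, known or untested is meant among the compounds shown, and "the series" means these compounds.

Compound 1 `COc1cc(C2=NOC(c3c[nH]c4ccccc34)C2)cc(OC)c1OC`: 5000 nM
Compound 2 `c1ccc2c(C3CC(c4ccncc4)=NO3)c[nH]c2c1`: > 100000 nM
Compound 3 `COc1ccc2[nH]cc(C3CC(c4ccncc4)=NO3)c2c1`: > 100000 nM

Within the data shown here, in a functional assay on HEK293 cells (Homo sapiens) for inhibition, read by MTT assay, with a stated time of 48 h (on this read-out higher numbers stand for weaker inhibition and lower numbers for stronger inhibition), compound 1 gives 5000 nM, the only number among the three measured compounds. For compound 2 the assay reports only a limit, > 100000 nM. For compound 3 the assay likewise reports only a limit, > 100000 nM. The change from compound 2 to compound 3 is methoxy in place of hydrogen on an aromatic carbon; the step that the two limits leave unreadable from compound 2 to compound 3 cannot be read, because both values sit at the limit of > 100000 nM in this assay, at which 2 of the 3 values shown sit. How the cores of compound 1 and compound 2 differ is not broken down here.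

Compound 4 `COc1ccc2[nH]cc(C3CC(c4cc(OC)c(OC)c(OC)c4)=NO3)c2c1` carries the same change on compound 1: methoxy in place of hydrogen on an aromatic carbon. The measured pair gives no readable size for this change, so the expectation rests on compound 1 alone. Compound 4 is expected to stay near compound 1, with a step of no change at the digits printed from compound 1 to compound 4 (within the scatter). Compound 4 is therefore estimated at 5000 nM, expected to fall between 1500 nM and 20000 nM.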

Compound 4, half-maximal inhibitory concentration: 45400 nM
Compound 4: middle estimate off by 9.1-fold (0.96 log units), on the low side; measured number above the stated range.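

In this assay, methoxy in place of hydrogen on an aromatic carbon gives a 9.1-fold higher number from compound 1 to compound 4 (0.96 log units; beyond the scatter), so on this core the change goes with weaker inhibition. On the core of compound 2 the same change cannot be read, because compound 2 and compound 3 both give an assay limit and not a number: the limit of > 100000 nM in this assay, at which 2 of the 4 values shown sit. The change therefore has a readable size on one core only, and the series does not show whether that size carries over to another core.

The compounds shown leave open whether hydroxy, fluoro or an amine on the same aromatic carbon would give a step like that of methoxy. They also leave open whether a longer ether chain there would do so.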